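The compounds below may be only part of what the source reports. "The series", "measured", "known", "first", "only" and "open" are said of these compounds alone.

Three compounds have numbers in a functional assay on CCRF-CEM cells (Homo sapiens) for inhibition, read by MTT assay, with a stated time of 2 days, tested at 10 uM; on this read-out lower numbers stand for less inhibition and higher numbers for more inhibition at the one concentration tested (going by the name of the read-out). Compound 1 `O=C(OCCCc1ccccc1)c1cc(-n2cc(-c3cccc(O)c3)nn2)ccc1O` gives 9%, compound 2 `COc1cc(OC)cc(-c2cn(-c3ccc(O)c(C(=O)O)c3)nn2)c1` gives 9%, and compound 3 `COc1ccccc1-c1cn(-c2ccc(O)c(C(=O)OCCCc3ccccc3)c2)nn1` gives 4%. Compound 2 stands level with compound 1 at the digits shown, and its gap to compound 3 is within the scatter. Among the measured compounds shown here, the one step between compounds differing in a single place, a number 5 percentage points lower from compound 1 to compound 3 (within the scatter), concerns a change on an aromatic carbon and stays within the scatter. Compound 4 `COc1cc(OC)cc(-c2cn(-c3ccc(O)c(C(=O)Nc4cccc(C(F)(F)F)c4)c3)nn2)c1` differs from compound 2 by (3-(trifluoromethyl)phenyl)amino in place of hydroxy on a carbonyl carbon. For the measured compounds named here, no measured step touches the carbonyl carbon, so nothing in the data points to a move beyond the scatter. The step expected in this assay is a number 6 percentage points higher from compound 2 to compound 4 (within the scatter). Compound 4 is expected at 15%, within a range from 0% to 45%.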

Compound 4, a percentage reported as inhibition, at one concentration (the size of the read-out at that concentration, not a potency): 73%
The estimate for compound 4 lay 58 percentage points below the measured number, and the stated range ends below it.
By their numbers in this assay, from the lowest: compounds 3, 1 and 2 (each within the scatter of the next); then compound 4.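

In this assay, the carbonyl carbon emerges as a place where one change moves the number beyond the scatter: a number 64 percentage points higher from compound 2 to compound 4 (beyond the scatter) with (3-(trifluoromethyl)phenyl)amino in place of hydroxy. Among the compounds shown here, the only earlier step, on an aromatic carbon, stayed within the scatter, so the earlier compounds showed no such move. No evidence bearing on the reason for this rise is available. The compounds shown leave open which part of the entering group carries the rise. From the compounds shown here alone, whether a plain phenylamino group or a methylamino group on this carbonyl carbon would give a similar number also remains open.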